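Sulfanyl to sulfonyl on the compound 3 scaffold

A few compounds are considered here, and "the series" means these few. Any claim that something is new, unique, unknown or untested is made for them only; others in the source may bear on it.

compound 1 `Cc1ccc(S(=O)(=O)/C(=C/c2ccc(C)s2)C(=O)c2ccc(Cl)cc2)cc1`: 50000 nM
compound 2 `Cc1ccc(S(=O)(=O)/C(=C/c2ccc(Cl)cc2)C(=O)c2ccc(Cl)cc2)cc1`: 1000 nM
compound 3 `COc1ccc(/C=C(/Sc2ccc(C)cc2)C(=O)c2ccc(Cl)cc2)cc1O`: 1000 nM

All three values come from a functional assay on DU-145 cells (Homo sapiens) for inhibition, read by trypan blue exclusion, with a stated time of 96 h; a higher number here means a weaker inhibitor of growth, a lower number a stronger inhibitor of growth. Compound 3 stands level with compound 2, and the two share the lowest of the three numbers, while compound 1 has the highest.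

The next compound to be measured is compound 4 `COc1ccc(/C=C(\C(=O)c2ccc(Cl)cc2)S(=O)(=O)c2ccc(C)cc2)cc1O`. Compared with compound 3, it has (4-methylphenyl)sulfonyl in place of (4-methylphenyl)sulfanyl on a double-bonded chain carbon bound to a carbonyl carbon and a double-bonded chain carbon.

No measured step makes this exchange, so its size and direction are not shown directly. Within the data shown here, the only measured step, a 50-fold lower number from compound 1 to compound 2 (1.70 log units; beyond the scatter), is large, but it concerns 4-chlorophenyl in place of 5-methylthiophen-2-yl. It bears only indirectly, showing that numbers among the compounds with (4-methylphenyl)sulfonyl can move widely. Compound 2 also carries (4-methylphenyl)sulfonyl and gives 1000 nM, which offers a nearby reference point. No step beyond the scatter is expected in this assay, though the uncertainty is wide. The expected change is a 1.4-fold lower number from compound 3 to compound 4 (0.15 log units; within the scatter). For compound 4 the estimated value is 700 nM, with an expected range of 100 nM to 7000 nM.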

Compound 4, concentration for 50% growth inhibition: 1000 nM
Beside the measured number, compound 4's estimate is 1.4-fold (0.15 log units) below it; measured number inside the range.
By their numbers in this assay, from the lowest: compounds 2, 3 and 4 (each within the scatter of the next); then compound 1.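

In this assay the exchange of (4-methylphenyl)sulfanyl for (4-methylphenyl)sulfonyl on a double-bonded chain carbon bound to a carbonyl carbon and a double-bonded chain carbon gives no change at the digits printed from compound 3 to compound 4 (within the scatter) and so, with 3-hydroxy-4-methoxyphenyl held in place, this position takes either group without a step beyond the scatter. Among the compounds with (4-methylphenyl)sulfonyl, 3-hydroxy-4-methoxyphenyl in place of 4-chlorophenyl gives no change at the digits printed from compound 2 to compound 4 (within the scatter) while 3-hydroxy-4-methoxyphenyl in place of 5-methylthiophen-2-yl gives a 50-fold lower number from compound 1 to compound 4 (1.70 log units; beyond the scatter) and thus, of these three compounds with (4-methylphenyl)sulfonyl, only compound 1 stands apart. Nothing available explains these numbers.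

Still open, going by these compounds, is whether the same exchange reads the same way with 4-chlorophenyl or 5-methylthiophen-2-yl in the place of 3-hydroxy-4-methoxyphenyl, as (4-methylphenyl)sulfanyl appears here only in compound 3. Also open, on these data alone, is how a (4-methylphenyl)sulfinyl group, an amide or a carboxylic acid would read on the same double-bonded chain carbon.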